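The compounds below may be only part of what the source reports. "The series", "measured", "known", "first", "only" and "open" are said of these compounds alone.

Measured so far in a physicochemical assay for solubility, in phosphate buffer, at pH 7.4; a higher number here means a more soluble compound, a lower number a less soluble compound:
- Compound 1 `CC(=O)N[C@@H]1CCC[C@H](C(=O)Nc2cc(-c3cnn4ccccc34)c(Cl)cn2)C1`: 45000 nM
- Compound 2 `CC(=O)N[C@@H]1CCC[C@H](C(=O)Nc2cc(-c3cnc4ccccn34)c(Cl)cn2)C1`: 120000 nM

Of these two numbers, the higher belongs to compound 2. The next compound, compound 3 `CC(=O)N[C@@H]1CCC[C@H](C(=O)Nc2cc(-c3nnn4ccccc34)c(Cl)cn2)C1`, differs from compound 2 in one place: a group of 9 heavy atoms (6 carbon, 3 nitrogen; one five-membered aromatic ring with 3 hetero atoms, one six-membered aromatic ring with 1 hetero atom) in place of a group of 9 heavy atoms (7 carbon, 2 nitrogen; one five-membered aromatic ring with 2 hetero atoms, one six-membered aromatic ring with 1 hetero atom), on an aromatic carbon. The exchange lies on an aromatic carbon, ortho to a chloro group and opposite the ring nitrogen.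

Going by the values given here, only one measured step bears on this change: a 2.7-fold higher number from compound 1 to compound 2 (0.43 log units; beyond the scatter). That step also exchanged one group of 9 heavy atoms for another on an aromatic carbon, and it was modest. A single step gives a rough scale for such an exchange but no reliable direction for a new group. In this assay, a shift of about that size is therefore expected to be the outer case, in either direction, and a smaller one is more likely. The expected change is slight and stays within the scatter: a 1.3-fold lower number from compound 2 to compound 3 (0.12 log units; within the scatter). The estimated value for compound 3 is 90000 nM, with an expected range of 35000 nM to 200000 nM.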

Compound 3, solubility: 530000 nM
Estimate against measurement, compound 3: 5.9-fold (0.77 log units) below; measured number outside the range, above it.
By their numbers in this assay, from the lowest: compound 1; then compound 2; then compound 3.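

The position, on an aromatic carbon ortho to a chloro group, proved able to carry much larger shifts than the earlier pair suggested: in this assay, the group with 3 hetero atoms in its five-membered aromatic ring gives a 4.4-fold higher number from compound 2 to compound 3 (0.65 log units; beyond the scatter) and a 12-fold higher number from compound 1 to compound 3 (1.07 log units; beyond the scatter). The second of these is large, so an exchange between groups of the same size, each with one six-membered aromatic ring with 1 hetero atom, can move this number substantially, and among these three compounds the entering group gives the highest value. Counted atoms alone do not order the series, as the two groups with 7 carbon and 2 nitrogen atoms still differ by a 2.7-fold higher number from compound 1 to compound 2 (0.43 log units; beyond the scatter), and nothing available here bears on the reason for any of these steps.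

The compounds shown leave open whether the higher number would survive a substituent such as a methyl group or an amine on the entering group. They also leave open whether the same exchange would give a step of similar size if a methoxy group stood in place of the chloro group.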